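This account rests on a few compounds, and the source may have more. Where it says the series, first, only, none or still open, it means among the compounds named here.

Compound 2 `CC(C)c1n[nH]c2c(NCc3ccc(-c4ccccn4)cc3)nc(SCC(C)(C)O)nc12` gives 507 nM in a functional assay on HT cells (Homo sapiens) for antiproliferative activity, read by fluorescence, with a stated time of 72 h (a higher number here means a weaker inhibitor of growth, a lower number a stronger inhibitor of growth), the higher of the two numbers recorded. Compound 1 `CC(C)c1n[nH]c2c(NCc3ccc(-c4ccccn4)cc3)nc(SCCn3ccnc3)nc12` gives 155 nM in this assay, and the change between them reads a 3.3-fold higher number from compound 1 to compound 2 (0.51 log units; beyond the scatter). Compound 3 `CC(C)c1n[nH]c2c(NCc3ccc(-c4ccccn4)cc3)nc(SCCN)nc12` differs from compound 2 in that (aminomethyl in place of 1-hydroxy-1-methylethyl on a saturated chain carbon bound to a sulfur). That single measured step is the only one at this place, and it was modest, so a further swap here is expected to move the number by a comparable amount at most. Compound 3 is therefore expected to show a 2.0-fold lower number from compound 2 to compound 3 (0.29 log units; within the scatter). The estimate for compound 3 is 260 nM, with a range from 80 nM to 850 nM.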

Compound 3, concentration for 50% growth inhibition: 22 nM
Beside the measured number, compound 3's estimate is 12-fold (1.07 log units) above it, outside the stated range (below it).
By their numbers in this assay, from the lowest: compound 3; then compound 1; then compound 2.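

In this assay, the step to the 2-aminoethyl chain on the sulfur is by far the largest seen at this place (a 23-fold lower number from compound 2 to compound 3 (1.36 log units; beyond the scatter)). Among the compounds shown here, replacing 1H-imidazol-1-yl with amino on the same chain also lowers the number (a 7.0-fold lower number from compound 1 to compound 3 (0.85 log units; beyond the scatter)), so compound 3 stands lowest of the three, and this place can move the number much further than the one earlier step showed. Nothing available explains this gain. As far as these compounds go, whether a longer chain, such as 3-aminopropyl, would keep it remains open, as does whether a dimethylamino group or a carboxylic acid at the chain end could stand in for the amine.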